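The source may hold more compounds than are shown below. What is called first, only, known or untested is meant among the compounds shown, and "the series" means these compounds.

Measured compounds in a physicochemical assay for permeability, using PAMPA; on this read-out higher numbers stand for higher permeability and lower numbers for lower permeability:
compound 1 `Cc1ccnc([C@@H](C)Oc2cc3oc(=O)n(CCC(=O)O)c3cc2Cl)c1`
compound 2 `O=C(O)CCn1c(=O)oc2cc(OCc3ccccn3)c(Cl)cc21`
compound 3 `C[C@@H](Oc1cc2oc(=O)n(CCC(=O)O)c2cc1Cl)c1ccc(Cl)cn1`.

Compound 1 gives < 3 nm/s, which is a limit of this assay and not a number. Compound 2 gives 11 nm/s and compound 3 gives 60 nm/s. Among the two numbers shown, compound 2 stands lowest, with compound 3 beyond the scatter above it; the third value is a limit.

Among the compounds with values here, the one measured step, an at least 20-fold higher number from compound 1 to compound 3 (1.30 log units; beyond the scatter), is large; it is tied to the limit of < 3 nm/s in this assay, at which 1 of the 3 values shown sits, since one end of it is only a limit.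

Compound 4 `COCCOc1cc2oc(=O)n(CCC(=O)O)c2cc1Cl` is not yet measured in this assay. It differs from compound 2 as follows: methoxymethyl in place of pyridin-2-yl on a saturated chain carbon bound to an oxygen on an aromatic ring. Within the data shown here, no measured step covers this change; the step from compound 1 to compound 3 alters the groups on the pyridine ring, while here the ring itself is replaced by a short chain. Without a direct precedent, the expectation rests on compound 2 alone, and a modest downward step in this assay is expected, a 1.8-fold lower number from compound 2 to compound 4 (0.26 log units; within the scatter), though within or near the scatter. Compound 4 is estimated at 6 nm/s, with a range from 2 nm/s to 20 nm/s; a reading at the limit of this assay cannot be excluded.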

Compound 4, apparent permeability: < 3 nm/s
Compound 4: no number, only a limit; the forecaster's own chance of this, stated with the estimate: 25%; middle value at least 2.0-fold (0.30 log units) away from the limit.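

In this assay compound 4 gives < 3 nm/s, which is a limit of the assay and not a number. At this place, on a saturated chain carbon bound to an oxygen on an aromatic ring, the pyridine ring itself can now be compared with an open chain: methoxymethyl in place of pyridin-2-yl gives an at least 3.6-fold lower number from compound 2 to compound 4 (0.56 log units; beyond the scatter), a change of a different kind from the earlier step, an at least 20-fold higher number from compound 1 to compound 3 (1.30 log units; beyond the scatter), in which the pyridine ring stays and only the groups on it differ. This new step has no fixed size, and only its lower bound can be read, since one of its ends is a limit: the limit of < 3 nm/s in this assay, at which 2 of the 4 values shown sit.

The compounds shown do not separate the loss of the ring from the particular chain that enters, so a phenyl ring in place of pyridin-2-yl, or a longer chain ending in an ethyl ether, would be needed to tell these apart. From the compounds shown here alone, all four compounds also carry the same carboxylic acid chain, so how this change reads with a primary amide in that place remains open.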